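A smaller amide on the shared core of compound 2

A few compounds are considered here, and "the series" means these few. Any claim that something is new, unique, unknown or untested is made for them only; others in the source may bear on it.

Measured compounds:
Compound 1 `N#CCNC(=O)[C@@H]1C[C@@H](S(=O)(=O)CC2CC2)C[C@H]1C(=O)N1CCOCC1` — 230 nM
Compound 2 `C[C@@H]1CN(C(=O)[C@@H]2C[C@H](S(=O)(=O)c3ccccc3)C[C@H]2C(=O)NC2(C#N)CC2)C[C@H](C)O1` — 0.4 nM
Compound 3 `CN1CCN(C(=O)[C@@H]2C[C@H](S(=O)(=O)c3ccccc3)C[C@H]2C(=O)NC2(C#N)CC2)CC1` — 2 nM

In an assay on isolated protein for inhibition of cathepsin S (Homo sapiens), read by fluorescence, with a stated time of 20 min (on this read-out higher numbers stand for weaker inhibition and lower numbers for stronger inhibition), compound 2 gives the lowest of the three numbers; compound 3 stands nearest, and compound 1, which differs from compound 2 in more than one place, stands furthest. Going by the values given here, the one single-point step measured on this core, a 5.0-fold higher number from compound 2 to compound 3 (0.70 log units; beyond the scatter), shows that exchanging the amide partner changes the number only modestly. Compound 4 `N#CC1(NC(=O)[C@@H]2C[C@@H](S(=O)(=O)c3ccccc3)C[C@H]2C(=O)N2CCCC2)CC1` is not yet measured. It differs from compound 2 by pyrrolidin-1-yl in place of 2,6-dimethylmorpholin-4-yl on a carbonyl carbon. Among the compounds with values here, no measured pair tells the effect of a pyrrolidin-1-yl amide, so the step from compound 2 to compound 3 is the only guide. By analogy with that step, a modest rise in the number is expected for compound 4, a 3.8-fold higher number from compound 2 to compound 4 (0.57 log units; beyond the scatter), with the possibility that it stays within the scatter of compound 2. The estimate for compound 4 in this assay is therefore 1.5 nM, with a range from 0.4 nM to 6 nM.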

Compound 4, half-maximal inhibitory concentration: 2 nM
Compound 4: the middle estimate sits 1.3-fold (0.12 log units) below what was measured, within the range that was stated.
By their numbers in this assay, from the lowest: compound 2; then compounds 3 and 4 (each within the scatter of the next); then compound 1.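

In this assay, the step of a 5.0-fold higher number from compound 2 to compound 4 (0.70 log units; beyond the scatter) shows that a second replacement for 2,6-dimethylmorpholin-4-yl on this carbonyl carbon also gives a higher number, so the earlier step no longer stands alone. Going by these compounds alone, the step of no change at the digits printed from compound 3 to compound 4 (within the scatter) adds that pyrrolidin-1-yl and 4-methylpiperazin-1-yl cannot be told apart here, leaving 2,6-dimethylmorpholin-4-yl as the only one of the three groups that stands apart on this core. Nothing available explains why this group gives the lowest number of the three.

As far as these compounds go, it remains open whether the difference follows the two methyl groups or the ring oxygen of 2,6-dimethylmorpholin-4-yl. Plain morpholin-4-yl and piperidin-1-yl on the same core would help separate these two features, and how either would read remains unknown.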